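This account rests on a few compounds, and the source may have more. Where it says the series, first, only, none or still open, it means among the compounds named here.

Compound 3 `CCCOCC(=O)Nc1cc2nc(C3CCCCC3)[nH]c2cc1N(CC)CC` in an ADME assay on Vero cells (Chlorocebus sabaeus) for cytotoxicity, read by resazurin assay, with a stated time of 3 days (on this read-out higher numbers stand for weaker inhibition and lower numbers for stronger inhibition), gives > 100 ug/mL, which is a limit of the assay and not a number. Compound 1 `CCOCCOC(=O)Nc1cc2nc(C3CCCCC3)[nH]c2cc1N(C)C` in this assay gives > 100 ug/mL, likewise a limit. Compound 2 `COc1ccc(C(=O)Nc2cc3nc(C4CCCCC4)[nH]c3cc2N(C)C)cc1` in this assay gives > 100 ug/mL, also a limit. The step that the two limits leave unreadable from compound 1 to compound 2 is unreadable, since both of its ends rest on (the limit of > 100 ug/mL in this assay, at which 3 of the 3 values shown sit), where every value shown so far sits. Compound 4 `CCCOCC(=O)Nc1cc2nc(C3CCCCC3)[nH]c2cc1N(C)C` carries dimethylamino in place of diethylamino on an aromatic carbon. For the measured compounds named here, no measured step bears on this change, and nothing so far shows any change carrying a compound away from the limit. The step that the limit leaves unreadable from compound 3 to compound 4 is therefore expected to stay within the scatter. Compound 4 is estimated at 150 ug/mL, with a range from 60 ug/mL to 400 ug/mL.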

Compound 4, half-maximal inhibitory concentration: < 50 ug/mL
Compound 4 ended at the assay's limit (the forecaster's own chance of this, stated with the estimate: 85%); at least 3.0-fold (0.47 log units) between middle value and limit.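

In this assay compound 4 gives < 50 ug/mL, which is a limit of the assay. Dimethylamino in place of diethylamino on an aromatic carbon gives the only readable step at this position, an at least 2.0-fold lower number from compound 3 to compound 4 (0.30 log units; that floor lies within the scatter). Dimethylamino alone does not set this result, since the same group is present across an at least 2.0-fold lower number from compound 2 to compound 4 (0.30 log units; that floor lies within the scatter) and across an at least 2.0-fold lower number from compound 1 to compound 4 (0.30 log units; that floor lies within the scatter), where propoxymethyl is the change on the carbonyl carbon.

From the compounds shown here alone, the true size of all three steps stays open, as does the unreadable step between the other two compounds. Also open, going by these compounds, is whether a pyrrolidine at this position, or a butoxymethyl chain on the carbonyl carbon, would behave the same way.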